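The source may report more compounds than this note shows. Statements on the series, on what has been measured and on what is new or still open speak of the compounds shown alone.

Going by the values given here, compound 3 `CC(=O)c1ccc2c(c1)nc(-c1ccccc1)n2C1CCCCC1` is the one member of this set with a number to its name: in an ADME assay on MT4 cells (Homo sapiens) for cytotoxicity, read by MTT assay, with a stated time of 96 h (a higher number here means that more compound is tolerated, a lower number that less compound is tolerated), compound 3 gives 37000 nM. The two related compounds with an unsubstituted nitrogen on the shared core, compound 1 `CC(=O)c1ccc2[nH]c(-c3ccccc3)nc2c1`, for which this assay records "not determined" (no result reported), and compound 2 `C/C(=N\NC(N)=O)c1ccc2[nH]c(-c3ccccc3)nc2c1`, for which this assay records "not determined" (no result reported), carry no result at all in this assay, so compound 3 cannot be placed against anything measured; its value stands alone as the sole reference point.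

Compound 4 `COc1ccc(-c2nc3cc(C(C)=O)ccc3n2C2CCCCC2)cc1` differs from compound 3 by a single change: methoxy in place of hydrogen on an aromatic carbon. Among the compounds with values here, no step between measured compounds of this kind is available, so the size of the effect of adding a methoxy group in this assay has to be judged without precedent. A change of this kind, on the ring that hangs off the shared core, would be expected to leave the tolerated concentration roughly where it is for compound 3, with at most a small move in either direction, and any shift of the expected size would sit inside the usual scatter of the assay, so no clear direction is claimed.

On that basis compound 4 is expected to give about 30000 nM in this assay, within a range of 10000 nM to 90000 nM, which corresponds to an expected step of a 1.2-fold lower number from compound 3 to compound 4 (0.09 log units; within the scatter).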

Compound 4, half-maximal cytotoxic concentration: 27000 nM
Compound 4: middle estimate off by 1.1-fold (0.05 log units), on the high side; low and high end bracket the measured number.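

In this assay, going by these compounds alone, the change from phenyl to 4-methoxyphenyl gives the first step in this set that can be read at all, a 1.4-fold lower number from compound 3 to compound 4 (0.14 log units; within the scatter), so compound 3 no longer stands alone as a single reference point. At this aromatic carbon, para to a large group, methoxy in place of hydrogen gives a difference that cannot be told apart from repeat measurement. Within the data shown here, this is one pair and one substituent, so it shows only that this particular change leaves the two compounds indistinguishable in this read-out, not that the position is indifferent to substitution in general.

From the compounds shown here alone, whether an amine, a carboxylic acid or a longer alkoxy chain at the same carbon would read the same remains open, as does the effect of methoxy elsewhere on that ring. Steps to compound 1 and compound 2 cannot be read, so what the group on the nitrogen of the shared core contributes in this assay also remains open. No measured property of these compounds bears on the result, so the similar readings of compound 3 and compound 4 go unexplained.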